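This account rests on a few compounds, and the source may have more. Where it says the series, first, only, none or still open, it means among the compounds named here.

Compound 1 `COc1ccccc1C#Cc1cc(Cl)cn2c([N+](=O)[O-])c(CS(=O)(=O)c3ccccc3)nc12` stands only at a limit of the numbers shown. In an ADME assay on HepG2 cells (Homo sapiens) for cytotoxicity, read by MTT assay, with a stated time of 72 h (on this read-out lower numbers stand for higher toxicity in this test and higher numbers for lower toxicity in this test), compound 1 gives > 3900 nM, which is a limit of the assay rather than a number. Compound 2 `O=[N+]([O-])c1c(CS(=O)(=O)c2ccccc2)nc2c(C#Cc3ccc(CO)cc3)cc(Cl)cn12` likewise gives only a limit in this assay, namely > 15600 nM. For the measured compounds named here, the one measured step, a step that the two limits leave unreadable from compound 1 to compound 2, bears on the change but cannot be read for size. Compound 3 `CC(O)C#Cc1cc(Cl)cn2c([N+](=O)[O-])c(CS(=O)(=O)c3ccccc3)nc12` differs from compound 1 by 1-hydroxyethyl in place of 2-methoxyphenyl on a triple-bonded carbon. No step beyond the scatter is expected in this assay, and compound 3 is estimated at 10000 nM, ranging from 3000 nM to 40000 nM. That estimate means an expected step that the limit leaves unreadable from compound 1 to compound 3.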

Compound 3, half-maximal cytotoxic concentration: 44200 nM
Compound 3: middle estimate off by 4.4-fold (0.65 log units), on the low side; measured number above the stated range.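

For the compounds shown here, no step to compound 3 can be read from compound 1 or compound 2, whose values in this assay are limits and not numbers. The compounds shown leave open how far compound 3 truly differs from either.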